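Swapping Ethoxy for Imidazolyl: An Expected Potency Shift

The source may report more compounds than this note shows. Statements on the series, on what has been measured and on what is new or still open speak of the compounds shown alone.

Measured compounds:
compound 1, `CCOc1ccc(C(=O)/C=C/c2ccc(N(C)C)cc2)cc1`, 210 nM
compound 2, `CCOc1ccc(C(=O)/C=C/c2ccc(Br)cc2)cc1`, 210 nM
compound 3, `CCOc1ccc(C(=O)/C=C/c2ccc(O)cc2)cc1`, 210 nM

In an assay on isolated protein for inhibition of Amine oxidase [flavin-containing] B (Homo sapiens) (on this read-out lower numbers stand for stronger inhibition and higher numbers for weaker inhibition), compound 2 gives 210 nM, level with compounds 1 and 3. The three measured steps, no change at the digits printed from compound 1 to compound 2 (within the scatter), no change at the digits printed from compound 1 to compound 3 (within the scatter) and no change at the digits printed from compound 2 to compound 3 (within the scatter), each exchange one group for another while the ethoxy stays in place. Compound 4, `O=C(/C=C/c1ccc(Br)cc1)c1ccc(-n2ccnc2)cc1`, differs from compound 2 at that ethoxy: 1H-imidazol-1-yl in place of ethoxy on an aromatic carbon. Within the data shown here, no measured step touches this position, so the data give no direct guide to how this exchange plays out. Compound 4 is therefore expected to remain an inhibitor, with a wider uncertainty than usual, and the estimated step is a 2.9-fold higher number from compound 2 to compound 4 (0.46 log units; beyond the scatter). The expected value for compound 4 is 600 nM, with a range from 150 nM to 2500 nM.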

Compound 4, half-maximal inhibitory concentration: 320 nM
The estimate for compound 4 lay 1.9-fold (0.27 log units) above the measured number, and the stated range covers the measured number.
By their numbers in this assay, from the lowest: compounds 1, 2, 3 and 4 (each within the scatter of the next).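

In this assay, this position now has a measured step: 1H-imidazol-1-yl in place of ethoxy gives a 1.5-fold higher number from compound 2 to compound 4 (0.18 log units; within the scatter), even though a five-membered aromatic ring replaces an open chain. With the bromo group held fixed, inhibition therefore survives this exchange on the aromatic carbon. No supporting evidence is available to explain this result. On these data alone, how an amine or a carboxylic acid would fare at this position remains open. Also open, as far as these compounds go, is whether 1H-imidazol-1-yl behaves the same way when dimethylamino or hydroxy replaces the bromo group.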